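The source may report more compounds than this note shows. Statements on the series, on what has been measured and on what is new or still open speak of the compounds shown alone.

Compound 2 `CCCN(CC[C@H]1CC[C@H](NC(=O)c2ccc3ccccc3n2)CC1)[C@H]1CCc2nc(N)sc2C1` gives 1.6 nM in an assay on brain for displacement of a labelled ligand from D(3) dopamine receptor (Rattus norvegicus) (a lower number here means a stronger inhibitor, a higher number a weaker inhibitor), the lowest of the two numbers measured; compound 1 `CCCN(CC[C@H]1CC[C@H](NC(=O)/C=C/c2cccc(F)c2)CC1)[C@H]1CCc2nc(N)sc2C1` gives 9.9 nM. Among the compounds with values here, the one measured step, a 6.2-fold lower number from compound 1 to compound 2 (0.79 log units; beyond the scatter), shows that exchanging the group on the carbonyl carbon can move the number well beyond the scatter. Compound 3 `CCCN(CC[C@H]1CC[C@H](NC(=O)c2ccccc2-n2cccn2)CC1)[C@H]1CCc2nc(N)sc2C1` carries 2-(1H-pyrazol-1-yl)phenyl in place of quinolin-2-yl on a carbonyl carbon. From the compounds shown here alone, this step bears on that same carbonyl position, yet the entering group has no measured partner here, so the direction remains open and a modest shift either way is plausible. Compound 3 is therefore expected to give 5 nM, with a range from 1.5 nM to 20 nM, an estimated step of a 3.1-fold higher number from compound 2 to compound 3 (0.49 log units; beyond the scatter).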

Compound 3, inhibition constant: 2 nM
For compound 3 the middle estimate is 2.5-fold (0.40 log units) above the measured one, and the stated range covers the measured number.
By their numbers in this assay, from the lowest: compounds 2 and 3 (each within the scatter of the next); then compound 1.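

In this assay, 2-(1H-pyrazol-1-yl)phenyl on the carbonyl carbon cannot be told apart from quinolin-2-yl, with a 1.3-fold higher number from compound 2 to compound 3 (0.10 log units; within the scatter). Two different two-ring groups therefore give matching results at this position, and both give a lower number than 2-(3-fluorophenyl)ethenyl, which for the new group is a 5.0-fold lower number from compound 1 to compound 3 (0.69 log units; beyond the scatter). Nothing available explains why these two groups match. The compounds shown leave open how a plain phenyl ring with no second ring would behave here. They also leave open the effect of a carboxylic acid or an amine on this phenyl ring.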